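This account rests on a few compounds, and the source may have more. Where it says the series, first, only, none or still open, it means among the compounds named here.

Measured so far in a functional assay on NSCLC cells (Homo sapiens) for cytotoxicity, with a stated time of 48 h; a higher number here means a weaker inhibitor of growth, a lower number a stronger inhibitor of growth:
- compound 1 `COc1cc2c(/C=C3/C(=O)Nc4ccc(O)cc43)c(Cl)n(Cc3cc(OC)c(OC)c(OC)c3)c2cc1C` gives 2400 nM
- compound 2 `COc1cc2c(/C=C3/C(=O)Nc4ccc(Cl)cc43)c(Cl)n(Cc3cc(OC)c(OC)c(OC)c3)c2cc1C` gives 2290 nM
- compound 3 `COc1cc2c(cc1C)NC(=O)/C2=C/c1c(Cl)n(Cc2cc(OC)c(OC)c(OC)c2)c2cc(C)c(OC)cc12` gives 11000 nM

Compound 3 stands highest of the three numbers in this assay. Its gap to compound 1 is beyond the usual scatter, and so is its gap to compound 2. Within the data shown here, the single measured step, a 1.0-fold lower number from compound 1 to compound 2 (0.02 log units; within the scatter), swaps one substituent on an aromatic carbon for another and leaves the number essentially where it was; it does not touch the ring that changes here, so it offers no guide to the direction of the next step.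

Compound 4 `COc1ccc2c(c1)/C(=C\c1c(Cl)n(Cc3cc(OC)c(OC)c(OC)c3)c3cc(C)c(OC)cc13)C(=O)N2` differs from compound 3 by hydrogen in place of methyl on an aromatic carbon. Among the measured compounds shown here, no measured pair removes a methyl from this position, so the series gives no measured precedent for the change. For the measured compounds named here, with the one known step lying within the scatter, the expectation is a step of no clear size or direction, a 1.2-fold lower number from compound 3 to compound 4 (0.09 log units; within the scatter), with wide uncertainty. Compound 4 is therefore expected near 9000 nM, in a range from 3000 nM to 27000 nM.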

Compound 4, concentration for 50% growth inhibition: 20400 nM
Estimate against measurement, compound 4: 2.3-fold (0.36 log units) below; the range from low to high includes it.
By their numbers in this assay, from the lowest: compounds 2 and 1 (each within the scatter of the next); then compounds 3 and 4 (each within the scatter of the next).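

In this assay, taking the methyl off this aromatic carbon, ortho to a methoxy group, gives a 1.9-fold higher number from compound 3 to compound 4 (0.27 log units; within the scatter); within the scatter, the methyl shows no clear contribution to the number in this pair. Among these compounds, the same compound also gives the first readings for the methoxy group on this ring, with an 8.9-fold higher number from compound 2 to compound 4 (0.95 log units; beyond the scatter) and an 8.5-fold higher number from compound 1 to compound 4 (0.93 log units; beyond the scatter), both beyond the scatter, whereas the earlier hydroxy and chloro pair lay within it. Among these compounds, then, methoxy at that place separates from both hydroxy and chloro, and no measurement on hand bears on the reason for these steps.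

Open, from the compounds shown here alone, is whether an amine or a carboxylic acid on this ring would sit with hydroxy and chloro or with methoxy. Also open, going by these compounds, is whether a longer chain on that oxygen would extend the methoxy step.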